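Removing the methoxy from the benzylamide of compound 1

A few compounds are considered here, and "the series" means these few. Any claim that something is new, unique, unknown or untested is made for them only; others in the source may bear on it.

Compound 1 `COc1ccc(CNC(=O)CSc2nc3ccc(NC(=O)c4ccc(Cl)cc4)cc3s2)cc1` is the reference of this small set. In a functional assay on HepG2 cells (Homo sapiens) for cytotoxicity, read by MTT assay, with a stated time of 48 h (a higher number here means a weaker inhibitor, a lower number a stronger inhibitor), compound 1 gives 7400 nM, the lowest of the two numbers reported, with compound 2 `COc1ccc(CNC(=O)CSc2nc3ccc(NC(C)=O)cc3s2)cc1` nearest: in this assay compound 2 gives 11200 nM, and a 1.5-fold higher number from compound 1 to compound 2 (0.18 log units; within the scatter). Compound 3 `COc1ccc(CNC(=O)CSc2nc3ccc(NC(=O)c4ccc([N+](=O)[O-])cc4)cc3s2)cc1` reaches only a limit of the assay, the limit of > 100000 nM in this assay, at which 1 of the 3 values shown sits: in this assay compound 3 gives > 100000 nM. The steps toward it are larger: an at least 13-fold higher number from compound 1 to compound 3 (1.13 log units; beyond the scatter), and an at least 8.9-fold higher number from compound 2 to compound 3 (0.95 log units; beyond the scatter).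

All three measured steps alter the acyl group on the amide nitrogen of the shared core. Compound 4 `O=C(CSc1nc2ccc(NC(=O)c3ccc(Cl)cc3)cc2s1)NCc1ccccc1` changes the other end of the molecule: hydrogen in place of methoxy on an aromatic carbon, the methoxy leaving from the aromatic ring of the benzylamide, para to a large group. Among the measured compounds shown here, no measured pair touches this part of the structure, so the measured steps give no direct guide, while the 4-chlorophenyl amide of compound 1, the end where the numbers did move, is kept unchanged. The expected step is therefore none beyond the scatter: no change at the digits printed from compound 1 to compound 4 (within the scatter) is the estimate. Compound 4 is expected to give 7400 nM in this assay, with a range from 3000 nM to 18000 nM.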

Compound 4, half-maximal inhibitory concentration: 25400 nM
Compound 4: middle estimate off by 3.4-fold (0.54 log units), on the low side; measured number outside the range, above it.
By their numbers in this assay, from the lowest: compounds 1 and 2 (each within the scatter of the next); then compound 4. At a limit, above all of these: compound 3.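

Hydrogen in place of methoxy on the aromatic ring gives, in this assay, a 3.4-fold higher number from compound 1 to compound 4 (0.54 log units; beyond the scatter), a modest step that shows the 4-methoxybenzyl end of the molecule is not a silent position. Among the compounds shown here, the earlier steps all altered the acyl group on the amide nitrogen, so this is the first measured sign that the number also responds at the far end of the molecule, even with the 4-chlorophenyl amide held constant. For the compounds shown here, the single change shows that the number moves, but nothing given here accounts for why it moves.

The compounds shown leave open whether a hydroxyl, an ethoxy or a fluoro group on the same aromatic carbon would stay close to compound 1 or move with compound 4, and so whether the oxygen or the whole methoxy group matters. They also leave open whether the same change would carry over to the acetyl amide of compound 2, and how a phenethyl group or a simple alkyl chain in place of the 4-methoxybenzyl group would read.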